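The source may hold more compounds than are shown below. What is called first, only, known or untested is meant among the compounds shown, and "the series" means these compounds.

In a functional assay on NALM-6 cells (Homo sapiens) for cytotoxicity, with a stated time of 72 h (a lower number here means that less compound is needed, a higher number that more compound is needed for the effect), compound 3 (`CC(C)=CCC[C@@](C)(/C=C/c1ccccc1)/C=C/c1ccc(O)cc1`) gives no number, only a limit (> 43400 nM). Compound 2 (`COc1ccc(/C=C/[C@@](C)(/C=C/c2ccc(O)cc2)CCC=C(C)C)cc1`) also gives only a limit (> 43400 nM). For the measured compounds named here, compound 1 (`COc1ccc(/C=C/[C@@](C)(/C=C/c2ccc(O)c(/C=C/C#N)c2)CCC=C(C)C)cc1`) is the only one with a number (16500 nM). Compound 4 (`CC(C)=CCC[C@](C)(/C=C/c1ccc(O)cc1)/C=C/c1ccc(C#N)cc1`) differs from compound 3 by cyano in place of hydrogen on an aromatic carbon and so carries 4-cyanophenyl in place of phenyl. Replacing 2-cyanoethenyl with hydrogen gave an at least 2.6-fold higher number from compound 1 to compound 2 (0.42 log units; beyond the scatter) and is the closest measured change, though that group differs from cyano and sits at another place, so it transfers only loosely. The methoxy change gave a step that the two limits leave unreadable from compound 2 to compound 3 and offers no size to use. A modest move to a lower number is therefore expected in this assay (an at least 1.5-fold lower number from compound 3 to compound 4 (0.19 log units; that floor lies within the scatter)), and a result at the limit remains possible. Compound 4 is estimated at 28000 nM with an expected range from 12000 nM to 60000 nM in this read-out.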

Compound 4, half-maximal effective concentration: > 43400 nM
Compound 4 was reported as a limit (the forecaster's own chance of this, stated with the estimate: 45%); middle value at least 1.5-fold (0.19 log units) away from the limit.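

In this assay compound 4, compound 3 and compound 2 all stand at a limit, so no step among them can be read: the limit of > 43400 nM in this assay, at which 3 of the 4 values shown sit.

From the compounds shown here alone, whether 4-cyanophenyl in place of phenyl changes the read-out at all remains open.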